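A few compounds are considered here, and "the series" means these few. Any claim that something is new, unique, unknown or untested is made for them only; others in the source may bear on it.

Within the data shown here, in an ADME assay on HepG2 cells (Homo sapiens) for cytotoxicity, read by MTT assay, with a stated time of 72 h (a lower number here means that less compound is tolerated, a higher number that more compound is tolerated), compound 2 (`O=[N+]([O-])c1c(CS(=O)(=O)c2ccccc2)nc2c(-c3ccccc3CO)cc(Cl)cn12`) gives 88000 nM, the only true number so far. Compound 1 (`O=[N+]([O-])c1c(CS(=O)(=O)c2ccccc2)nc2c(-c3ccc(Cl)cc3)cc(Cl)cn12`) gives > 3900 nM, which is a limit and not a number. Compound 3 (`O=[N+]([O-])c1c(CS(=O)(=O)c2ccccc2)nc2c(-c3cccc(F)c3)cc(Cl)cn12`) differs from compound 2 by 3-fluorophenyl in place of 2-(hydroxymethyl)phenyl on an aromatic carbon, with 3-fluorophenyl in place of 2-(hydroxymethyl)phenyl on an aromatic carbon. Among the measured compounds shown here, the one measured step at this place is a step that the limit leaves unreadable from compound 1 to compound 2, so it gives no size to carry over. For the measured compounds named here, the only pointer is compound 1, which like compound 3 has a halogen-bearing phenyl and no hydroxymethyl group, and which stands at the limit of > 3900 nM in this assay, at which 1 of the 2 values shown sits. A move beyond the scatter towards lower numbers is therefore expected in this assay, though its size is poorly fixed. The estimated step is a 4.4-fold lower number from compound 2 to compound 3 (0.64 log units; beyond the scatter). Compound 3 is expected at 20000 nM, with an estimated range of 5000 nM to 70000 nM.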

Compound 3, half-maximal cytotoxic concentration: > 12500 nM
Compound 3 was reported as a limit (the forecaster's own chance of this, stated with the estimate: 45%); the middle value is on the limit's open side.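

Compound 3 gives > 12500 nM, which is a limit and not a number. Its steps from compound 2 and from compound 1 therefore cannot be read. The compounds shown leave open how far compound 1 and compound 3 truly lie from compound 2 in this assay, and how those two compare with each other.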